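This account rests on a few compounds, and the source may have more. Where it says the series, first, only, none or still open, it means among the compounds named here.

Compound 1 `Cc1ccc(Nc2cc(NC(=O)Nc3c(Cl)cccc3Cl)ncn2)cc1C`: 92.1%
Compound 2 `COc1cc(NC(=O)Nc2cc(Nc3ccc(C)c(C)c3)ncn2)cc(OC)c1`: 66%
Compound 3 `COc1cc(Br)ccc1Nc1cc(NC(=O)Nc2c(Cl)cccc2Cl)ncn1`: 90.5%

All three were tested in a functional assay on PC-9 cells (Homo sapiens) for inhibition, read by MTT assay, with a stated time of 48 h, tested at 10 uM; a higher number here means more inhibition at the concentration tested (going by the name of the read-out), a lower number less inhibition. On these numbers compound 2 stands lowest of the three: compound 3 is nearest to it and compound 1 furthest, both beyond the scatter. Compound 4 `CCc1cccc(Nc2cc(NC(=O)Nc3cc(OC)cc(OC)c3)ncn2)c1` has not yet been measured. It differs from compound 2 in one place: 3-ethylphenyl in place of 3,4-dimethylphenyl on a nitrogen on an aromatic ring. Among the compounds with values here, the one measured step that bears on this is a number 1.6 percentage points lower from compound 1 to compound 3 (within the scatter), also a swap of the group on that nitrogen, made on a pair whose other aromatic group differs from that of compound 2; it stayed within the scatter. On that single precedent, no step beyond the scatter is expected, so the expected step is no change at the digits printed from compound 2 to compound 4 (within the scatter). Compound 4 is therefore estimated at 66%, with a range from 50% to 82%.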

Compound 4, a percentage reported as inhibition, at one concentration (the size of the read-out at that concentration, not a potency): 82.1%
Compound 4: the middle estimate sits 16.1 percentage points below what was measured, outside the stated range (above it).
By their numbers in this assay, from the lowest: compound 2; then compounds 4, 3 and 1 (each within the scatter of the next).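

The group on this nitrogen can matter: 3-ethylphenyl in place of 3,4-dimethylphenyl gives a number 16.1 percentage points higher from compound 2 to compound 4 (beyond the scatter), although both groups have 8 carbon heavy atoms and one aromatic ring. Rearranging the same number of carbons on this ring is therefore enough to move the read-out beyond the scatter, unlike the swap in a number 1.6 percentage points lower from compound 1 to compound 3 (within the scatter), which was made with a different second aromatic group. Nothing shown gives a reason for this rise.

On these data alone, whether the same swap would change the read-out with the other aromatic group of compound 1 remains open. So does the effect of a longer chain, such as propyl, or an amine on this ring.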